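Fluorine for hydroxyl on the styryl arm of compound 1

The source may report more compounds than this note shows. Statements on the series, on what has been measured and on what is new or still open speak of the compounds shown alone.

Of the compounds shown here, three sharing one core have been measured in a functional assay on HL-60 cells (Homo sapiens) for cytotoxicity, read by WST assay, with a stated time of 48 h; a higher number here means a weaker inhibitor, a lower number a stronger inhibitor. Compound 1 `Oc1cccc(/C=C/C[C@H]2C[C@@H]([C@@H](O)c3ccccc3)CO[C@@H]2c2ccccc2)c1` gives 12800 nM. Compound 2 `O[C@@H](c1ccccc1)[C@H]1CO[C@H](c2ccccc2)[C@@H](C/C=C/c2cccc(F)c2)C1` gives 9170 nM, and compound 3 `Oc1ccc(/C=C/C[C@H]2C[C@@H]([C@@H](O)c3ccccc3)CO[C@@H]2c2ccccc2)cc1` gives 7380 nM. Compound 1 shows the highest of the three numbers, yet its steps to the other two are both within the scatter: a 1.4-fold lower number from compound 1 to compound 2 (0.14 log units; within the scatter), and a 1.7-fold lower number from compound 1 to compound 3 (0.24 log units; within the scatter). The pair compound 2 and compound 3 likewise show a 1.2-fold lower number from compound 2 to compound 3 (0.09 log units; within the scatter).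

Compound 4 `O[C@@H](c1ccccc1)[C@H]1CO[C@H](c2ccccc2)[C@@H](C/C=C/c2ccccc2F)C1` has not yet been measured. Relative to compound 1 it carries 2-fluorophenyl in place of 3-hydroxyphenyl on a double-bonded chain carbon bound to a double-bonded chain carbon. Among the compounds with values here, two measured steps bear on this change. The replacement of a hydroxy by a fluoro on the aromatic ring is seen in a 1.4-fold lower number from compound 1 to compound 2 (0.14 log units; within the scatter), and the shift of the substituent to another position of that ring is seen in a 1.7-fold lower number from compound 1 to compound 3 (0.24 log units; within the scatter). Within the data shown here, neither moved the number beyond the scatter, and nothing among the measured compounds hints that combining a fluoro with this position should behave differently. In this assay compound 4 is therefore expected to give about the same number as compound 1, with a 1.3-fold lower number from compound 1 to compound 4 (0.13 log units; within the scatter) expected to lie within the scatter. The estimate for compound 4 is 9500 nM, with a range from 4000 nM to 22000 nM.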

Compound 4, half-maximal inhibitory concentration: 9530 nM
The estimate for compound 4 lay 1.0-fold (0.00 log units) below the measured number, within the range that was stated.
By their numbers in this assay, from the lowest: compounds 3, 2, 4 and 1 (each within the scatter of the next).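

In this assay the 2-fluorophenyl group fits the pattern of the other aryl groups on the double-bonded chain carbon: the change gives a 1.3-fold lower number from compound 1 to compound 4 (0.13 log units; within the scatter) and also a 1.3-fold higher number from compound 3 to compound 4 (0.11 log units; within the scatter) for the other hydroxy compound. The earlier compounds had shown only the 3-fluorophenyl group, and moving to the 2-fluorophenyl group gives a 1.0-fold higher number from compound 2 to compound 4 (0.02 log units; within the scatter), so the two fluorinated compounds cannot be told apart and the place of the fluoro on this ring has no readable effect on the number here. Although the 3-hydroxyphenyl group carries a hydrogen-bond donor and a hydrogen-bond acceptor and the 2-fluorophenyl group carries neither, the number stays within the scatter, and no measurement at hand explains why these groups cannot be told apart.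

The compounds shown leave open whether any group at this place can move the number beyond the scatter, as each of them is a phenyl bearing a single hydroxy or fluoro. A phenyl bearing an amine or a carboxylic acid, or a longer chain in place of the prop-2-en-1-yl link, would test this, and the shared core, the same in all four compounds, remains equally unexplored.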